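The compounds below may be only part of what the source reports. "The series", "measured", "known", "first", "only" and "open" are said of these compounds alone.

Compound 1 `COc1cccc(/C=C2\CCC/C(=C\c3cccc(OC)c3OC)C2=O)c1` and compound 2 `COc1ccc(/C=C2\CCC/C(=C\c3cccc(OC)c3OC)C2=O)cc1` share one core and differ in a single aromatic group: 4-methoxyphenyl in place of 3-methoxyphenyl on a double-bonded chain carbon bound to a double-bonded ring carbon. In a functional assay on HT-1080 cells (Homo sapiens) for cytotoxicity, read by MTT assay, with a stated time of 72 h (on this read-out lower numbers stand for stronger inhibition and higher numbers for weaker inhibition), compound 1 gives 9900 nM, and compound 2 gives 16300 nM. That change gave a 1.6-fold higher number from compound 1 to compound 2 (0.22 log units; within the scatter), so the two numbers cannot be ordered with confidence. Compound 3 `COc1cccc(/C=C2\CCC/C(=C\c3ccc(OC)c(OC)c3)C2=O)c1` carries a different aromatic group, and the difference between its core and the core of compound 1 is not broken down here. In this assay compound 3 gives 4600 nM, the lowest number of the three and beyond the scatter from both compound 1 and compound 2. Compound 4 `COc1ccc(/C=C2\CCC/C(=C\c3ccc(OC)c(OC)c3)C2=O)cc1` is yet to be measured. It differs from compound 3 by the same change already seen between compound 1 and compound 2: 4-methoxyphenyl in place of 3-methoxyphenyl on a double-bonded chain carbon bound to a double-bonded ring carbon. Because the earlier change gave a 1.6-fold higher number from compound 1 to compound 2 (0.22 log units; within the scatter), the step from compound 3 to compound 4 is expected to be small as well, estimated as a 1.5-fold higher number from compound 3 to compound 4 (0.18 log units; within the scatter). Compound 4 is therefore expected to give about 7000 nM in this assay, with a likely range from 3500 nM to 14000 nM.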

Compound 4, half-maximal inhibitory concentration: 7200 nM
Compound 4: the middle estimate sits 1.0-fold (0.01 log units) below what was measured; the measured number falls inside the stated range.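

In this assay, putting 4-methoxyphenyl in place of 3-methoxyphenyl on a double-bonded chain carbon bound to a double-bonded ring carbon gave a 1.6-fold higher number from compound 3 to compound 4 (0.19 log units; within the scatter), so these two numbers cannot be ordered with confidence. Set beside the earlier step, the change carries over between the two cores without a detectable difference: the same change on two cores in this assay, a 1.6-fold higher number (0.22 log units; within the scatter) from compound 1 to compound 2 and a 1.6-fold higher number (0.19 log units; within the scatter) from compound 3 to compound 4, 1.1-fold (0.02 log units) apart, within the scatter of two such steps. This shows that the swap made only a small step on both cores, but since each step lies within the scatter, it does not show that the change has a real effect in either direction, and two cores cannot establish a rule for the whole series.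

The compounds shown leave open what happens when the methoxy group on this aromatic ring gives way to a different group, such as a hydroxyl, an amine or a carboxylic acid. They also leave open whether the step stays small on a core whose other aromatic group is a plain phenyl.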